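Aryl imine series: hydroxy added beside methoxy

The compounds below may be only part of what the source reports. "The series", "measured", "known", "first", "only" and "open" are said of these compounds alone.

Measured compounds: compound 1 `Cc1c(/N=C/c2ccccc2Cl)c(=O)n(-c2ccccc2)n1C`, 309000000 nM; compound 2 `COc1cccc(/C=N/c2c(C)n(C)n(-c3ccccc3)c2=O)c1`, 155000000 nM; compound 3 `Cc1c(/N=C/c2ccccc2)c(=O)n(-c2ccccc2)n1C`, 851000000 nM.

All numbers come from a functional assay on HT-29 cells (Homo sapiens) for cytotoxicity, read by MTT assay, with a stated time of 72 h; a lower number here means a stronger inhibitor, a higher number a weaker inhibitor. Compound 2 gives the lowest number of the set, though its gap to compound 1 is small: a 2.0-fold lower number from compound 1 to compound 2 (0.30 log units; within the scatter). Against compound 3 the gap is larger, a 5.5-fold higher number from compound 2 to compound 3 (0.74 log units; beyond the scatter), and compound 3 also sits above compound 1: a 2.8-fold higher number from compound 1 to compound 3 (0.44 log units; beyond the scatter).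

Compound 4 `COc1cccc(/C=N/c2c(C)n(C)n(-c3ccccc3)c2=O)c1O` is not yet measured. Its change from compound 2 is hydroxy in place of hydrogen on an aromatic carbon. Among the measured compounds shown here, two measured steps bear on it, both in the same aryl ring: removal of chloro, a 2.8-fold higher number from compound 1 to compound 3 (0.44 log units; beyond the scatter), and removal of methoxy, a 5.5-fold higher number from compound 2 to compound 3 (0.74 log units; beyond the scatter). Both show that a substituent on this ring lowers the number by a modest amount, and compound 4 adds a further one, so a modest step downward or one within the scatter is the expectation. Nothing measured here involves a hydroxy, so the estimate stays wide. The expected step is a 1.6-fold lower number from compound 2 to compound 4 (0.19 log units; within the scatter). For compound 4 in this assay the estimate is 100000000 nM, with a range from 40000000 nM to 250000000 nM.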

Compound 4, half-maximal inhibitory concentration: 240000000 nM
Compound 4: the middle estimate sits 2.4-fold (0.38 log units) below what was measured; low and high end bracket the measured number.
By their numbers in this assay, from the lowest: compounds 2, 4 and 1 (each within the scatter of the next); then compound 3.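

Hydroxy in place of hydrogen, on an aromatic carbon ortho to a methoxy group, gives (a 1.5-fold higher number from compound 2 to compound 4 (0.19 log units; within the scatter)) in this assay, so this position tolerates the change without a step that can be read as real in either direction. The earlier steps shown here, chloro (a 2.8-fold higher number from compound 1 to compound 3 (0.44 log units; beyond the scatter)) and methoxy (a 5.5-fold higher number from compound 2 to compound 3 (0.74 log units; beyond the scatter)), tied a substituent on this aryl ring to a difference beyond the scatter, but compound 4 goes against any rule that each further substituent lowers the number, and that pattern now rests only on compound 1 and compound 2. Nothing available accounts for the absence of a clear step at this position, and the result stands as an observation only.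

On these data alone, whether an amine, a carboxylic acid or a second methoxy group in place of this hydroxy would give a step beyond the scatter stays open. Also open is whether hydroxy would behave the same way on an aryl ring that carries no methoxy group, which the compounds shown cannot separate.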